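This account rests on a few compounds, and the source may have more. Where it says the series, first, only, none or still open, it means among the compounds named here.

Measured so far in a functional assay on PC-3 cells (Homo sapiens) for cytotoxicity, read by sulforhodamine B assay, with a stated time of 72 h; on this read-out lower numbers stand for stronger inhibition of growth and higher numbers for weaker inhibition of growth:
- compound 1, `CCCCCCCCC(=O)N1c2ccccc2CCC1C(=O)Nc1ccccc1C(F)(F)F`: 4320 nM
- compound 2, `O=C(Nc1cc(C(F)(F)F)cc(C(F)(F)F)c1)C1CCc2ccccc2N1C(=O)c1ccc(Cl)cc1`: 4230 nM
- compound 3, `O=C(Nc1ccccc1O)C1CCc2ccccc2N1C(=O)c1ccccc1`: 5690 nM

All three numbers sit within the usual scatter of one another, so compound 1 neither stands apart from compound 2 nor from compound 3; the three share a core and differ only in the groups on its nitrogen and on the amide. Compound 4, `O=C(Nc1ccccc1C(F)(F)F)C1CCc2ccccc2N1`, has not yet been tested in this assay. It differs from compound 1 as follows: hydrogen in place of octylcarbonyl on a nitrogen on an aromatic ring in a ring. Among the compounds with values here, no measured pair shows what removing the group on that nitrogen does, so the expectation rests on the spread of the three values alone. A small step toward weaker inhibition, a 1.9-fold higher number from compound 1 to compound 4 (0.27 log units; within the scatter), is expected, giving an estimated 8000 nM for compound 4, with a range from 2500 nM to 30000 nM.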

Compound 4, concentration for 50% growth inhibition: 53300 nM
Estimate against measurement, compound 4: 6.7-fold (0.82 log units) below; measured number above the stated range.
By their numbers in this assay, from the lowest: compounds 2, 1 and 3 (each within the scatter of the next); then compound 4.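

Going from octylcarbonyl to hydrogen on this nitrogen in this assay gives a 12-fold higher number from compound 1 to compound 4 (1.09 log units; beyond the scatter) and this is the first change in the series to stand clear of the scatter. It shows that growth inhibition in this series depends strongly on what sits at this place, which the three earlier compounds, all within the scatter of one another, could not reveal. Nothing available explains the size of this step. Still open, going by these compounds, is whether the carbonyl or the long chain carries the effect. An acetyl group or a plain octyl chain on this nitrogen would separate the two.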